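Compound 3 to compound 4 under the limits alone

A few compounds are considered here, and "the series" means these few. Any claim that something is new, unique, unknown or untested is made for them only; others in the source may bear on it.

Compound 1 `Cc1nc(-c2ccccc2NCC2=NCCN2)cs1` in a functional assay for activation of Alpha-1D adrenergic receptor (Homo sapiens) (on this read-out higher numbers stand for an effect only at larger amounts of compound and lower numbers for an effect already at smaller amounts), gives < 5020 nM, a limit of the assay and not a number.
Compound 2 `Cc1ccc(-c2ccccc2NCC2=NCCN2)o1` gives < 2000 nM, again a limit.
Compound 3 `CO/N=C(\C)c1ccccc1NCC1=NCCN1` gives < 5020 nM, also a limit.

Compound 3 therefore stands at a limit only, with the two other values likewise limits (the limit of < 2000 nM in this assay, at which 1 of the 3 values shown sits, (the limit of < 5020 nM in this assay, at which 2 of the 3 values shown sit)). The steps a step that the two limits leave unreadable from compound 1 to compound 2, a step that the two limits leave unreadable from compound 1 to compound 3 and a step that the two limits leave unreadable from compound 2 to compound 3 are all of unreadable size. Compound 4 `CC/C(=N\OC)c1ccccc1NCC1=NCCN1` differs from compound 3 by methyl in place of hydrogen on a saturated chain carbon bound to a carbon with a double bond to nitrogen. Among the compounds with values here, no measured step reads on this change, so for compound 4 the step that the limit leaves unreadable from compound 3 to compound 4 is expected to stay within the scatter. Compound 4 is estimated at 1500 nM, within 150 nM to 5020 nM.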

Compound 4, half-maximal effective concentration: < 100000 nM
Compound 4: a limit, no number (the forecaster's own chance of this, stated with the estimate: 60%); the middle value lies beyond the limit too.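

Compound 4 gives only a limit in this assay, as do compound 1, compound 2 and compound 3, so none of its steps to them can be read. The compounds shown leave open what methyl to ethyl does to the read-out, and whether these four compounds differ at all.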